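Lengthening the Nitrogen Substituent in a Cytotoxicity Series

The source may hold more compounds than are shown below. What is called first, only, known or untested is meant among the compounds shown, and "the series" means these compounds.

Compound 3 `CC(C)N(c1ccnc(Nc2ccc(C#N)cc2)n1)c1c(F)cc(-c2ccc(C#N)cc2)cc1F` gives 172000 nM in an ADME assay on MT4 cells (Homo sapiens) for cytotoxicity, read by MTT assay, with a stated time of 5 days (a lower number here means that less compound is tolerated, a higher number that more compound is tolerated), the second highest of the three numbers measured. Its nearest neighbour is compound 1 `CN(c1ccnc(Nc2ccc(C#N)cc2)n1)c1c(F)cc(-c2ccc(C#N)cc2)cc1F`, which gives 148000 nM, and the step of a 1.2-fold higher number from compound 1 to compound 3 (0.07 log units; within the scatter) lies within the scatter. Compound 2 `CCCCN(c1ccnc(Nc2ccc(C#N)cc2)n1)c1c(F)cc(-c2ccc(C#N)cc2)cc1F` gives 211000 nM, and the step of a 1.2-fold lower number from compound 2 to compound 3 (0.09 log units; within the scatter) is likewise within the scatter. Compound 4 `CCC(C)CN(c1ccnc(Nc2ccc(C#N)cc2)n1)c1c(F)cc(-c2ccc(C#N)cc2)cc1F` differs from compound 3 by 2-methylbutyl in place of isopropyl on a nitrogen on an aromatic ring. Among the compounds with values here, the steps that bear on this change are a 1.4-fold higher number from compound 1 to compound 2 (0.15 log units; within the scatter) and a 1.2-fold lower number from compound 2 to compound 3 (0.09 log units; within the scatter), both within the scatter, so no step beyond the scatter is expected in this assay. Compound 4 is therefore estimated at 190000 nM, with a range from 110000 nM to 320000 nM. The expected step of a 1.1-fold higher number from compound 3 to compound 4 (0.04 log units; within the scatter) should stay within the scatter.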

Compound 4, half-maximal cytotoxic concentration: > 255000 nM
Compound 4 ended at the assay's limit; the forecaster's own chance of this, stated with the estimate: 10%; middle value at least 1.3-fold (0.12 log units) away from the limit.
By their numbers in this assay, from the lowest: compounds 1, 3 and 2 (each within the scatter of the next). At a limit, above all of these: compound 4.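

In this assay compound 4 stands at a limit, not at a number: the limit of > 255000 nM in this assay, at which 1 of the 4 values shown sits. Lengthening the nitrogen substituent to 2-methylbutyl therefore gives only floors (an at least 1.4-fold higher number from compound 3 to compound 4 (0.17 log units; that floor lies within the scatter); an at least 1.2-fold higher number from compound 2 to compound 4 (0.08 log units; that floor lies within the scatter); an at least 1.7-fold higher number from compound 1 to compound 4 (0.23 log units; that floor lies within the scatter)), and the true size of each step cannot be read. Where the earlier compounds all gave numbers, this position now also carries 2-methylbutyl with no step to a lower number. The compounds shown leave open whether a chain carrying an amine or a carboxylic acid on this nitrogen would give a number below the limit.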